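The source may hold more compounds than are shown below. What is called first, only, known or untested is meant among the compounds shown, and "the series" means these compounds.

Among the measured compounds shown here, compound 3 `CN(C)CC[C@H](CSc1ccccc1)Nc1ccc(S(=O)(=O)NC(=O)c2ccc(N3CCC(=Cc4ccccc4Cl)CC3)cc2)cc1[N+](=O)[O-]` stands at the high end of the three numbers measured so far. In a functional assay (FL5.12 cells, Mus musculus) with Apoptosis regulator Bcl-2 (Homo sapiens) as the target (a lower number here means that less compound is needed, a higher number that more compound is needed for the effect), compound 3 gives 450 nM. Compound 1 `COC1(Cc2ccccc2C)CCN(c2ccc(C(=O)NS(=O)(=O)c3ccc(N[C@H](CCN(C)C)CSc4ccccc4)c([N+](=O)[O-])c3)cc2)CC1` gives 200 nM in this assay, and compound 2 `COC1(Cc2ccccc2Br)CCN(c2ccc(C(=O)NS(=O)(=O)c3ccc(N[C@H](CCN(C)C)CSc4ccccc4)c([N+](=O)[O-])c3)cc2)CC1` gives 200 nM; both of those numbers lie beyond the scatter below that of compound 3, so compound 3 needs more material for the same effect. Compound 4 `CN(C)CC[C@H](CSc1ccccc1)Nc1ccc(S(=O)(=O)NC(=O)c2ccc(N3CCC(=Cc4cccnc4)CC3)cc2)cc1[N+](=O)[O-]` differs from compound 3 in one place: pyridin-3-yl in place of 2-chlorophenyl on a double-bonded chain carbon bound to a double-bonded ring carbon. For the measured compounds named here, no measured pair repeats this exchange of 2-chlorophenyl for pyridin-3-yl. Going by the values given here, the only step that bears on it at all is a change of substituent on an aromatic carbon, no change at the digits printed from compound 1 to compound 2 (within the scatter), which left the number where it was. That step exchanged one group for another on an otherwise unchanged ring, whereas here the ring itself is replaced, so it is a weak guide. With nothing pointing to a large move in either direction, the expectation for compound 4 is a number close to that of compound 3, with wide uncertainty. The estimate for compound 4 is 500 nM, between 180 nM and 1500 nM. That estimate means a step of a 1.1-fold higher number from compound 3 to compound 4 (0.05 log units; within the scatter), expected to stay within the scatter.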

Compound 4, half-maximal effective concentration: 5300 nM
For compound 4 the middle estimate is 11-fold (1.03 log units) below the measured one; measured number outside the range, above it.
By their numbers in this assay, from the lowest: compounds 1 and 2 (each within the scatter of the next); then compound 3; then compound 4.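

The position on the double-bonded chain carbon bound to a double-bonded ring carbon proves highly sensitive in this assay, where pyridin-3-yl in place of 2-chlorophenyl gives a 12-fold higher number from compound 3 to compound 4 (1.07 log units; beyond the scatter) and much more compound is needed for the same effect. The earlier pair gave no change at the digits printed from compound 1 to compound 2 (within the scatter) with bromo in place of methyl on an aromatic carbon, so it showed only that one substituent could stand in for another on a ring that stayed in place, whereas this step shows that replacing the whole ring can matter a great deal. The change removes a chlorine and a carbon-only ring and brings in a ring with one hetero atom and one hydrogen-bond acceptor, but no measurement here explains why the number moves so far.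

From the compounds shown here alone, it remains open whether the step follows from losing the chlorine, from gaining the ring nitrogen, or from both together. A plain phenyl group at this place would help separate the two, as would a chloropyridinyl group, which carries both the chlorine and the ring nitrogen.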